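Furan for Thiophene, Tried on a Second Core

The source may report more compounds than this note shows. Statements on the series, on what has been measured and on what is new or still open speak of the compounds shown alone.

Three compounds have been measured in an assay on HeLa cells for displacement of a labelled ligand from adenosine receptor A3 (Homo sapiens), read by radioligand binding, with a stated time of 180 min, tested at 1 uM; a higher number here means more inhibition at the concentration tested (going by the name of the read-out), a lower number less inhibition:

compound 1 `CC(C)OC(=O)C1=C(C(F)(F)F)NC(=O)NC1c1ccsc1`: 3%
compound 2 `CC(C)OC(=O)C1=C(C(F)(F)F)NC(=O)NC1c1ccoc1`: 1%
compound 3 `CC1=C(C(=O)OCC(F)(F)F)C(c2ccsc2)NC(=O)N1`: 1%

All three numbers sit low, and they lie within the scatter of one another, so no order among them can be read. Compound 2 differs from compound 1 by one change, (furan-3-yl in place of thiophen-3-yl on a saturated ring carbon), and the step it made was a number 2 percentage points lower from compound 1 to compound 2 (within the scatter).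

Compound 4 `CC1=C(C(=O)OCC(F)(F)F)C(c2ccoc2)NC(=O)N1` is not yet measured. It differs from compound 3 by furan-3-yl in place of thiophen-3-yl on a saturated ring carbon. Among the measured compounds shown here, this is the same kind of change as the one from compound 1 to compound 2, made on a different core: in compound 1 the saturated ring carbon sits next to the ring atom that bears an isopropoxycarbonyl group and two ring bonds from the ring atom that bears a trifluoromethyl group, whereas in compound 3 it sits next to the ring atom that bears a group of 8 heavy atoms and two ring bonds from the ring atom that bears a methyl group. The difference between the two cores is not broken down here.

Because a number 2 percentage points lower from compound 1 to compound 2 (within the scatter) stayed within the scatter, the step from compound 3 to compound 4 is expected to be no change at the digits printed from compound 3 to compound 4 (within the scatter). Compound 4 is therefore estimated at 1%, between -5% and 7%.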

Compound 4, a percentage reported as inhibition, at one concentration (the size of the read-out at that concentration, not a potency): 1%
Beside the measured number, compound 4's estimate shows no gap at the digits printed; low and high end bracket the measured number.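

In this assay, putting furan-3-yl in place of thiophen-3-yl on the saturated ring carbon gives no change at the digits printed from compound 3 to compound 4 (within the scatter). Set beside the same change on the core of compound 1, the two results agree: the same change on two cores in this assay, a number 2 percentage points lower (within the scatter) from compound 1 to compound 2 and no change at the digits printed (within the scatter) from compound 3 to compound 4, 2 percentage points apart, within the scatter of two such steps This shows that the swap left no readable mark on either core, but all four numbers sit low, so the agreement is between two results close to the bottom of the scale and says little about how the change would carry over in a compound with clear inhibition; a reading at one concentration also gives no potency.

The compounds shown leave open whether any group on that ring carbon can lift the reading in this assay, since only these two five-membered aromatic rings appear there. From the compounds shown here alone, it also remains open what an amine or a carboxylic acid at that place, or a longer chain in place of the isopropoxycarbonyl group, would do.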